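A few compounds are considered here, and "the series" means these few. Any claim that something is new, unique, unknown or untested is made for them only; others in the source may bear on it.

Measured so far in a functional assay on HeLa cells (Homo sapiens) for cytotoxicity, read by MTT assay, with a stated time of 48 h, tested at 100 uM; a lower number here means a weaker effect, a higher number a stronger effect of the compound at the concentration tested:
compound 1 `CS(=O)(=O)c1ccc(Cc2n[nH]c(=S)n2/N=C/c2c(F)cccc2Cl)cc1` gives 77.3%
compound 2 `CS(=O)(=O)c1ccc(Cc2n[nH]c(=S)n2/N=C/c2ccc(F)cc2)cc1` gives 57.8%
compound 3 `CS(=O)(=O)c1ccc(Cc2n[nH]c(=S)n2/N=C/c2ccccc2Cl)cc1` gives 76.5%

Compound 2 stands lowest of these three numbers. Its nearest neighbour is compound 3, the step being a number 18.7 percentage points higher from compound 2 to compound 3 (beyond the scatter); the gap to compound 1 is the reverse of a number 19.5 percentage points lower from compound 1 to compound 2 (beyond the scatter). Between compound 1 and compound 3 the step is a number 0.8 percentage points lower from compound 1 to compound 3 (within the scatter), so the two compounds with a chlorine-bearing ring sit close together.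

Compound 4 `CS(=O)(=O)c1ccc(Cc2n[nH]c(=S)n2/N=C/c2cccs2)cc1` differs from compound 2 in one place: thiophen-2-yl in place of 4-fluorophenyl on a carbon with a double bond to nitrogen. The two measured steps that bear on this both leave the 4-fluorophenyl of compound 2 and both raise the read-out by a modest amount, but each brings in a chlorine-bearing six-membered ring, not a five-membered ring with one hetero atom. So no step of the same kind exists, and the direction of this assay for compound 4 is uncertain; a rise no larger than those seen, or none beyond the scatter, seems the most reasonable expectation.

Compound 4 is therefore estimated at 65%, in the range from 50% to 80%. The expected step is a number 7.2 percentage points higher from compound 2 to compound 4 (within the scatter).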

Compound 4, a percentage reported as activity, at one concentration (the size of the read-out at that concentration, not a potency): 61.1%
Estimate against measurement, compound 4: 3.9 percentage points above; the measured number falls inside the stated range.
By their numbers in this assay, from the lowest: compounds 2 and 4 (each within the scatter of the next); then compounds 3 and 1 (each within the scatter of the next).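

In this assay, thiophen-2-yl on the carbon with a double bond to nitrogen cannot be told apart from 4-fluorophenyl, with a number 3.3 percentage points higher from compound 2 to compound 4 (within the scatter) as the step, so a five-membered aromatic ring with one hetero atom and this six-membered ring read alike here. Set against the chlorine-bearing rings, the same thiophen-2-yl gives a number 15.4 percentage points lower from compound 3 to compound 4 (beyond the scatter) and also a number 16.2 percentage points lower from compound 1 to compound 4 (beyond the scatter) as its steps, so among these four compounds the split runs between rings with and without chlorine, not between ring sizes. No measurement shown gives a reason for this split.

A thiophen-2-yl ring carrying chlorine would test whether chlorine has the same link to the read-out on a five-membered ring. As far as these compounds go, how a ring bearing an amine or a carboxylic acid would read at this place also remains open.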